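Compound 2 and its longer carbamoyl chain

The compounds below may be only part of what the source reports. "The series", "measured", "known", "first", "only" and "open" are said of these compounds alone.

In a functional assay on OVCAR-8 cells (Homo sapiens) for antiproliferative activity (a lower number here means a stronger inhibitor, a higher number a weaker inhibitor), compound 2 (`Cn1ncc(Cl)c1-c1cc(C(=O)N[C@@H]2CN[C@H](CCCO)C[C@H]2c2ccc(Cl)c(Cl)c2)oc1Cl`) gives 600 nM. Compound 3 (`CNC(=O)C[C@@H]1C[C@@H](c2ccc(F)c(F)c2)[C@H](NC(=O)c2cc(-c3c(Cl)cnn3C)c(Cl)o2)CN1`) gives 800 nM, within the scatter of that number, and compound 1 (`Cn1ncc(Cl)c1-c1cc(C(=O)N[C@@H]2CN[C@H](CCNS(C)(=O)=O)C[C@H]2c2ccc(F)c(F)c2)oc1Cl`) gives 1530 nM, beyond the scatter of it. Compound 4 (`Cn1ncc(Cl)c1-c1cc(C(=O)N[C@@H]2CN[C@H](CC(=O)NCC(O)CO)C[C@H]2c2ccc(Cl)c(Cl)c2)oc1Cl`) has not yet been measured. It differs from compound 2 by one change, (2,3-dihydroxypropyl)carbamoyl in place of 2-hydroxyethyl on a saturated chain carbon bound to a saturated ring carbon. For the measured compounds named here, only one measured step touches a chain at this place: a 1.9-fold lower number from compound 1 to compound 3 (0.28 log units; within the scatter), with methylcarbamoyl in place of (methanesulfonamido)methyl. That step is small, but compound 1 and compound 3 also differ from compound 2 elsewhere, so it is only a loose guide. Compound 3, whose chain also holds a carbamoyl, stands at 800 nM, so no large departure is expected. The expected step is a 1.5-fold higher number from compound 2 to compound 4 (0.18 log units; within the scatter), toward a higher number but within the scatter. In this assay, the estimate for compound 4 is 900 nM, with an expected range of 400 nM to 2000 nM.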

Compound 4, half-maximal inhibitory concentration: 5900 nM
Compound 4: the middle estimate sits 6.6-fold (0.82 log units) below what was measured; measured number above the stated range.
By their numbers in this assay, from the lowest: compounds 2, 3 and 1 (each within the scatter of the next, the first and the last beyond it); then compound 4.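

Placing (2,3-dihydroxypropyl)carbamoyl in place of 2-hydroxyethyl on a saturated chain carbon bound to a saturated ring carbon gives, in this assay, a 9.8-fold higher number from compound 2 to compound 4 (0.99 log units; beyond the scatter). For the compounds shown here, the only earlier step at this place, a 1.9-fold lower number from compound 1 to compound 3 (0.28 log units; within the scatter), gave no sign that the chain could matter, whereas this step shows that the number can respond to what the chain carries. Nothing measured on these compounds accounts for the rise.

The step swaps the whole chain end at once, so the compounds shown do not separate the contribution of the carbamoyl from that of the two hydroxyl groups of the 2,3-dihydroxypropyl part. From the compounds shown here alone, how an amine or a carboxylic acid at the end of this chain would read in this assay also remains open.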